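Three naphthyl-bearing analogues and a carboxymethoxy variant

The compounds below may be only part of what the source reports. "The series", "measured", "known", "first", "only" and "open" are said of these compounds alone.

Compound 1 `COc1ccc(C(c2ccccc2O)c2cccc3ccccc23)c(OC)c1OC` was tested in a functional assay on A549 cells (Homo sapiens) for inhibition, read by sulforhodamine B assay, with a stated time of 48 h (on this read-out higher numbers stand for weaker inhibition and lower numbers for stronger inhibition), where compound 1 gives 13600 nM. Two companions were measured alongside it: compound 2 `COc1ccc(/C(=N/O)c2cccc3ccccc23)c(OC)c1OC` gives 13100 nM and compound 3 `C=CCC(O)(c1ccc(OC)c(OC)c1OC)c1cccc2ccccc12` gives 10700 nM. All three numbers sit within the usual scatter of one another, so no ranking among them can be drawn.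

Compound 4 `COc1ccc(C(c2ccc(OCC(=O)O)cc2)c2cccc3ccccc23)c(OC)c1OC` has not been measured. Its relation to compound 1 is 4-(carboxymethoxy)phenyl in place of 2-hydroxyphenyl on a saturated chain carbon bound to two aromatic carbons. Among the compounds with values here, no measured pair in this set shares that change, so there is no comparable step to lean on. With the three known values all close together, the expected step from compound 1 to compound 4 is a 1.5-fold higher number from compound 1 to compound 4 (0.17 log units; within the scatter), a modest move toward a weaker reading, not clearly beyond the scatter. Compound 4 is therefore expected to give about 20000 nM, with a plausible range from 7000 nM to 60000 nM.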

Compound 4, half-maximal inhibitory concentration: 16400 nM
Compound 4: the middle estimate sits 1.2-fold (0.09 log units) above what was measured; the measured number falls inside the stated range.
By their numbers in this assay, from the lowest: compounds 3, 2, 1 and 4 (each within the scatter of the next).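

In this assay, placing 4-(carboxymethoxy)phenyl where compound 1 carries 2-hydroxyphenyl gives a 1.2-fold higher number from compound 1 to compound 4 (0.08 log units; within the scatter), so this saturated chain carbon accepts a larger group carrying a carboxylic acid without a clear shift in the reading. The whole group is replaced in one step, so the contribution of each part cannot be separated. Nothing available explains this result.

Going by these compounds, it remains open whether an amine or a longer chain on this phenyl ring would stay within the scatter. Also open, on these data alone, is whether any group here can move the reading beyond it.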